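A few compounds are considered here, and "the series" means these few. Any claim that something is new, unique, unknown or untested is made for them only; others in the source may bear on it.

Compound 1 `O=C(/C=C/c1ccc(OCCCCCO[N+](=O)[O-])c(O)c1)OCCCCCO[N+](=O)[O-]` and compound 3 `COc1cc(/C=C/C(=O)OCCCCCO[N+](=O)[O-])ccc1OCCCCCO[N+](=O)[O-]` form a measured pair in a functional assay on cells (Homo sapiens) for cytotoxicity, read by resazurin assay, with a stated time of 72 h; a lower number here means a stronger inhibitor, a higher number a weaker inhibitor. In this assay compound 1 gives > 50000 nM, a limit of the assay rather than a number. Compound 3 gives > 50000 nM in this assay, again a limit of the assay. The change between them is methyl in place of hydrogen on an oxygen on an aromatic ring. Because both ends sit at the limit of > 50000 nM in this assay, at which 3 of the 3 values shown sit, the step that the two limits leave unreadable from compound 1 to compound 3 cannot be read as a size.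

Compound 2 `O=C(/C=C/c1ccc(OCCCCCCO[N+](=O)[O-])c(O)c1)OCCCCCCO[N+](=O)[O-]` belongs to a second core; the difference between the two cores is not broken down here. In this assay compound 2 gives > 50000 nM, which is a limit of the assay and not a number. The compound not yet measured, compound 4 `COc1cc(/C=C/C(=O)OCCCCCCO[N+](=O)[O-])ccc1OCCCCCCO[N+](=O)[O-]`, is reached from compound 2 by methyl in place of hydrogen on an oxygen on an aromatic ring. For the measured compounds named here, this is the same kind of change as the one from compound 1 to compound 3, and the two place descriptions agree word for word.

Going by the values given here, since the only measured instance of this change leaves both partners at the limit, and compound 2 itself also stands at that limit, compound 4 is expected to stay there as well. The expected step that the limit leaves unreadable from compound 2 to compound 4 is therefore one of essentially no readable movement. On that basis compound 4 is estimated to give about 60000 nM in this assay, with a likely span from 30000 nM to 200000 nM, most probably reported only as a limit.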

Compound 4, half-maximal inhibitory concentration: > 50000 nM
Compound 4 gave a limit, no number (the forecaster's own chance of this, stated with the estimate: 90%); the middle value does not contradict the limit.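

The step from compound 2 to compound 4, hydroxy to methoxy, cannot be read as a size, since both compounds stand at a limit of this assay and not at a number: the limit of > 50000 nM in this assay, at which 4 of the 4 values shown sit.

The compounds shown leave open whether hydroxy to methoxy changes the value at all in this assay, where none of the four gives a number.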